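Swapping Fluoro for Chloro on the Phenyl Ring

A few compounds are considered here, and "the series" means these few. Any claim that something is new, unique, unknown or untested is made for them only; others in the source may bear on it.

Measured so far in a functional assay on HeLa cells (Homo sapiens) for antiproliferative activity, read by MTT assay, with a stated time of 72 h; a lower number here means a stronger inhibitor, a higher number a weaker inhibitor:
compound 1 `O=c1nc2oc(CCCCl)c(C#CCCCCl)c2cn1Cc1cn(-c2ccc(Cl)cc2)nn1` gives > 100000 nM
compound 2 `O=c1nc2oc(C3CC3)cc2cn1Cc1cn(-c2ccc(Cl)cc2)nn1` gives > 100000 nM
compound 3 `O=c1nc2oc(CCCCl)cc2cn1Cc1cn(-c2ccc(F)cc2)nn1` gives 6990 nM

Compound 1 sits at the limit of > 100000 nM in this assay, at which 2 of the 3 values shown sit; its value is a limit of this assay, not a number. Compound 2 sits at that same limit. For the measured compounds named here, compound 3 is therefore the only compound of the three with an actual number in this assay, and it stands alone: no other measured compound differs from it in a single place, so no measured step can be read.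

Compound 4 `O=c1nc2oc(CCCCl)cc2cn1Cc1cn(-c2ccc(Cl)cc2)nn1` has not yet been measured. It differs from compound 3 by chloro in place of fluoro on an aromatic carbon. Compound 1 and compound 2 both carry the 4-chlorophenyl, but each also differs from compound 4 elsewhere, so they give no direct reading of this change.

The step of a 1.7-fold higher number from compound 3 to compound 4 (0.23 log units; within the scatter) is expected to be small, toward a weaker inhibitor, and close to the usual scatter. Compound 4 is estimated at 12000 nM, within a range from 3000 nM to 60000 nM.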

Compound 4, half-maximal inhibitory concentration: 60200 nM
Beside the measured number, compound 4's estimate is 5.0-fold (0.70 log units) below it; the whole stated range lies below it.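

In this assay, for the compounds shown here, the change from 4-fluorophenyl to 4-chlorophenyl gives the first reading of a single change, a modest step: an 8.6-fold higher number from compound 3 to compound 4 (0.94 log units; beyond the scatter). This shows that the choice of halogen on this aromatic carbon matters, with the 3-chloropropyl group and the shared core held constant, and that in this pair the fluoro compound is the stronger inhibitor. The other two steps give only a floor: an at least 1.6-fold lower number from compound 2 to compound 4 (0.22 log units; that floor lies within the scatter), and an at least 1.6-fold lower number from compound 1 to compound 4 (0.22 log units; that floor lies within the scatter). Neither can be read further, because each starts from a limit rather than a number: the limit of > 100000 nM in this assay, at which 2 of the 4 values shown sit.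

On these data alone, whether hydrogen, a methoxy group or a nitrile on this carbon would give a lower or a higher number remains open. So does whether the same change would have a similar effect with a cyclopropyl group or a longer chain in place of the 3-chloropropyl.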